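This account rests on a few compounds, and the source may have more. Where it says the series, first, only, none or still open, it means among the compounds named here.

Compound 1, `N#Cc1ccc(-c2cnc(N)c(-c3ccc(N)nc3)n2)cc1`, gives > 90% in an ADME assay on microsomes from liver (Homo sapiens) for metabolic stability, read by LC-MS, using NADPH, with a stated time of 30 min, tested at 0.1 uM, in the presence of a further agent that is not named here (on this read-out lower numbers stand for a less stable compound and higher numbers for a more stable compound), and this value is a limit of the assay rather than a number.
Compound 2, `Nc1ncc(-c2ccc(C(=O)O)cc2)nc1-c1ccc(C(F)(F)F)cc1`, gives > 90%, again a limit.
Compound 3, `Nc1ncc(-c2ccc(C(=O)N3CCC(O)CC3)cc2)nc1-c1ccc(C(F)(F)F)cc1`, gives > 90%, also a limit.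

Compound 3 therefore stands at the top edge of what the assay can report, and it shares that position with the two other measured compounds, since all three values shown sit at the limit of > 90% in this assay, at which 3 of the 3 values shown sit. Going by the values given here, the one measured step between single-point neighbours, a step that the two limits leave unreadable from compound 2 to compound 3, cannot be read in size, because both of its ends rest on (the limit of > 90% in this assay, at which 3 of the 3 values shown sit).

Compound 4, `Nc1ncc(-c2ccc(C(=O)N3CC[C@H](O)C3)cc2)nc1-c1ccc(C(F)(F)F)cc1`, has not been measured. It differs from compound 3 by 3-hydroxypyrrolidin-1-yl in place of 4-hydroxypiperidin-1-yl on a carbonyl carbon.

Among the compounds with values here, no measured step offers a readable size for this kind of change, and every compound measured so far has come back at the limit. The expectation is that compound 4 behaves like compound 3, with a step that the limit leaves unreadable from compound 3 to compound 4, which is expected to be none beyond the scatter. Compound 4 is thus estimated at 92%, with an expected range from 80% to 100%.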

Compound 4, percent of the compound remaining: > 90%
Compound 4: only a limit was reported; the forecaster's own chance of this, stated with the estimate: 80%; the middle value lies beyond the limit too.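

In this assay compound 4 gives > 90%, a limit and not a number, so the steps linking compound 4 to compound 2 and compound 3 cannot be read: the limit of > 90% in this assay, at which 4 of the 4 values shown sit. The compounds shown leave open whether these four truly differ in stability, and by how much.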